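The source may hold more compounds than are shown below. What is called first, only, known or untested is meant among the compounds shown, and "the series" means these compounds.

Compound 1 `COc1ccc2c(c1)c(-c1cc(C(F)(F)F)c(C#N)c(-c3cn(S(=O)(=O)c4ccc(C)cc4)c4ccc(OC)cc34)n1)cn2S(=O)(=O)c1ccc(C)cc1` was tested in a functional assay on A549 cells (Homo sapiens) for cytotoxicity; on this read-out lower numbers stand for stronger inhibition and higher numbers for weaker inhibition. From the compounds shown here alone, for compound 1 the assay reports only a limit, > 100000 nM, so its true potency is unknown beyond that point. A smaller relative, compound 2 `Cc1ccc(S(=O)(=O)n2cc(-c3cc(C(F)(F)F)ccn3)c3ccccc32)cc1`, gives 25000 nM in this assay. Among the two values shown, compound 1 therefore sits at the limit of > 100000 nM in this assay, at which 1 of the 2 values shown sits, and nothing places it more precisely.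

Compound 3 `COc1ccc2c(c1)c(-c1cc(C(F)(F)F)cc(-c3cn(S(=O)(=O)c4ccc(C)cc4)c4ccc(OC)cc34)n1)cn2S(=O)(=O)c1ccc(C)cc1` has not yet been measured. It differs from compound 1 in a single spot: hydrogen in place of cyano on an aromatic carbon. Going by the values given here, no measured pair shows what this swap does, so the expectation for the step from compound 1 to compound 3 is estimated as a number no higher from compound 1 to compound 3 (the limit leaves the size open), not clearly beyond the scatter in either direction. Compound 3 is accordingly expected to give about 100000 nM in this assay, most likely between 30000 nM and 300000 nM, with a real chance that only a limit is reported again.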

Compound 3, half-maximal inhibitory concentration: > 100000 nM
Compound 3: only a limit was reported (the forecaster's own chance of this, stated with the estimate: 60%); the middle value lies on the limit itself.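

In this assay, compound 1 and compound 3 each give only a limit, so the step between them cannot be read: the limit of > 100000 nM in this assay, at which 2 of the 3 values shown sit.

The compounds shown leave open how far past that limit either true value lies, and whether hydrogen in place of cyano changes the read-out at all.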